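The source may hold more compounds than are shown below. What is called first, only, known or untested is meant among the compounds shown, and "the series" means these compounds.

Compound 2 `Cc1ccc(-c2cs/c(=N/NC(=O)CSc3ncccn3)n2-c2ccccc2)cc1` is the starting point of this step. In an ADME assay on NIH3T3 cells (Mus musculus) for cytotoxicity, read by MTT assay, with a stated time of 24 h (a lower number here means a stronger inhibitor, a higher number a weaker inhibitor), compound 2 reaches only the limit of the assay, > 500 ug/mL, so no number is known for it. For the measured compounds named here, the one measured step that leads to it begins at compound 1 `O=C(CSc1ncccn1)N/N=c1/scc(-c2ccc(Cl)cc2)n1-c1ccccc1`, which in this assay gives 397 ug/mL. That step, an at least 1.2-fold higher number from compound 1 to compound 2 (0.10 log units; that floor lies within the scatter), reaches only a floor, and the floor stands within the scatter, because the limit of > 500 ug/mL in this assay, at which 1 of the 2 values shown sits, is the ceiling at which compound 2 sits. The change now followed is methoxy in place of methyl on an aromatic carbon, giving compound 3 `COc1ccc(-c2cs/c(=N/NC(=O)CSc3ncccn3)n2-c2ccccc2)cc1`. Going by the values given here, only a single measured step bears on it, and that step showed nothing beyond the scatter, so for the exchange of methyl for methoxy there is no ground to expect a step in this assay in either direction beyond the scatter. Compound 3 is therefore estimated at 500 ug/mL, with a range from 330 ug/mL to 750 ug/mL. The step this estimate implies, a number no higher from compound 2 to compound 3 (the limit leaves the size open), is expected to stay within the scatter, and compound 3 is expected most likely to reach the same limit of the assay as compound 2 did.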

Compound 3, half-maximal inhibitory concentration: 450 ug/mL
For compound 3 the middle estimate is 1.1-fold (0.05 log units) above the measured one, within the range that was stated.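

In this assay the methoxy group on this aromatic carbon, para to a large group, gives compound 3 a measured value of 450 ug/mL, so this position now holds a true number for a group other than chloro. Against the chloro group the exchange reads as a 1.1-fold higher number from compound 1 to compound 3 (0.05 log units; within the scatter), so chloro and methoxy at this place cannot be told apart in this assay. Compound 2 gives only a limit, > 500 ug/mL, and the exchange of its methyl for methoxy can be read only as an at least 1.1-fold lower number from compound 2 to compound 3 (0.04 log units; that floor lies within the scatter), which shows no change beyond the scatter and leaves the full size of the step unknown because of a limit: the limit of > 500 ug/mL in this assay, at which 1 of the 3 values shown sits.

The compounds shown leave open whether an amine, a carboxylic acid or a longer chain such as butoxy at this place would move the number in this assay beyond the scatter. They also leave open the true value of compound 2 and whether a change elsewhere on the shared core, rather than at this position, would shift the number at all.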